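Notes on the shared core: phenyl for phenylcarbamoyl

This account rests on a few compounds, and the source may have more. Where it says the series, first, only, none or still open, it means among the compounds named here.

Compound 3 `Cc1nc2nc(C(=O)Nc3ccccc3)nn2c(-c2ccc(Cl)cc2Cl)c1CN` has been measured in an assay on isolated protein for inhibition of Dipeptidyl peptidase 9 (Homo sapiens) (a lower number here means a stronger inhibitor, a higher number a weaker inhibitor), where compound 3 gives > 10000 nM, which is a limit of the assay and not a number. Its two companions on the shared core are compound 1 `Cc1nc2cc(-c3ccco3)nn2c(-c2ccc(Cl)cc2Cl)c1CN` and compound 2 `Cc1nc2cc(-c3ccccc3)nn2c(-c2ccc(Cl)cc2Cl)c1CN`. In this assay compound 1 gives > 30000 nM, a limit only. In this assay compound 2 gives > 20000 nM, again a limit. Going by the values given here, every value in the set therefore sits at a limit (the limit of > 10000 nM in this assay, at which 1 of the 3 values shown sits, (the limit of > 20000 nM in this assay, at which 1 of the 3 values shown sits), (the limit of > 30000 nM in this assay, at which 1 of the 3 values shown sits)), and the only measured step, a step that the two limits leave unreadable from compound 1 to compound 2, cannot be read in size or direction. The change from compound 3 to compound 4 `Cc1nc2nc(-c3ccccc3)nn2c(-c2ccc(Cl)cc2Cl)c1CN` is phenyl in place of phenylcarbamoyl on an aromatic carbon. Among the compounds with values here, no measured step bears directly on this change; compound 2 also carries phenyl and shows only a limit, which gives no foothold for a gain. Compound 4 is expected to give 30000 nM in this assay, within 5000 nM to 150000 nM, most likely reported as a limit once more. The step that the limit leaves unreadable from compound 3 to compound 4 is accordingly expected to stay within the scatter.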

Compound 4, inhibition constant: > 30000 nM
Compound 4: no number, only a limit; the forecaster's own chance of this, stated with the estimate: 75%; the middle value sits exactly at the limit.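

Compound 3 and compound 4 both give only limits in this assay, and the step between them cannot be read in size or direction. The compounds shown leave open whether any substituent on the shared core gives a measurable inhibition constant.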